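Swapping benzyl for cyclopentyl in a low-toxicity series

The source may report more compounds than this note shows. Statements on the series, on what has been measured and on what is new or still open speak of the compounds shown alone.

Measured in a toxicity assay on THP-1 cells (Homo sapiens) for inhibition; on this read-out lower numbers stand for higher toxicity in this test and higher numbers for lower toxicity in this test:
Compound 1 `COc1ccc(-c2cnc(NC(=O)c3ccc(F)cc3)n2Cc2ccccc2)cc1`: > 100000 nM
Compound 2 `COc1ccc(-c2cnc(NC(=O)c3ncc[nH]3)n2C)cc1`: > 100000 nM

Compound 1 stands at > 100000 nM, which is a limit of the assay and not a number. Compound 2 shows > 100000 nM, which is also a limit. Together, the two compounds give (the limit of > 100000 nM in this assay, at which 2 of the 2 values shown sit), and neither has a numerical value.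

Compound 3 `COc1ccc(-c2cnc(NC(=O)c3ccc(F)cc3)n2C2CCCC2)cc1` keeps the core of compound 1 and has cyclopentyl in place of benzyl on an aromatic nitrogen. For the measured compounds named here, no step between measured compounds is available to guide the expectation. In this assay, no change beyond the scatter is expected, in either direction, and the estimated a number no higher from compound 1 to compound 3 (the limit leaves the size open) reflects this. The expectation rests on compound 1, whose > 100000 nM is a limit. For compound 3 the estimate is 100000 nM, with an expected range from 40000 nM to 250000 nM.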

Compound 3, half-maximal cytotoxic concentration: > 100000 nM
Compound 3 ended at the assay's limit; the forecaster's own chance of this, stated with the estimate: 75%; the middle value sits exactly at the limit.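

For the compounds shown here, compound 1 and compound 3 both end at a limit of the assay and not at a number, so no step between them can be read in this assay here: the limit of > 100000 nM in this assay, at which 3 of the 3 values shown sit. The compounds shown leave open whether cyclopentyl in place of benzyl on an aromatic nitrogen changes the read-out in this assay at all.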